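The source may report more compounds than this note shows. Statements on the series, on what has been measured and on what is new or still open speak of the compounds shown alone.

Compound 3 `CN1C[C@H](C(=O)Nc2ccc(F)c(Cl)c2)[C@@H](c2ccc(/C=C/C(=O)Nc3ccccc3N)cc2)C1` gives 34 mL/min/kg in an in vitro ADME assay on microsomes from liver (Mus musculus) for pharmacokinetics, read by LC-MS, with a stated time of 10 min, tested at 1 uM (on this read-out higher numbers stand for fast clearance and lower numbers for slow clearance), and lies within the scatter of compound 1 `CN1C[C@H](C(=O)Nc2ccccc2)[C@@H](c2ccc(/C=C/C(=O)Nc3ccccc3N)cc2)C1` at 67 mL/min/kg and of compound 2 `CC(C)c1ccc(NC(=O)[C@H]2CN(C)C[C@@H]2c2ccc(/C=C/C(=O)Nc3ccccc3N)cc2)cc1` at 54 mL/min/kg on this read-out. The still unmeasured compound 4 `Cc1cc(NC(=O)[C@H]2CN(C)C[C@@H]2c2ccc(/C=C/C(=O)Nc3ccccc3N)cc2)ccc1Cl` differs from compound 3 by 4-chloro-3-methylphenyl in place of 3-chloro-4-fluorophenyl on an amide-type nitrogen and thus carries 4-chloro-3-methylphenyl in place of 3-chloro-4-fluorophenyl on an amide-type nitrogen. Two measured steps changed the group on that nitrogen. These are a 2.0-fold lower number from compound 1 to compound 3 (0.29 log units; within the scatter) for 3-chloro-4-fluorophenyl in place of phenyl and a 1.6-fold lower number from compound 2 to compound 3 (0.20 log units; within the scatter) for 3-chloro-4-fluorophenyl in place of 4-isopropylphenyl. The step of a 1.2-fold lower number from compound 1 to compound 2 (0.09 log units; within the scatter) adds isopropyl to the same aromatic group. All three stay within the scatter, although none of them involves the 4-chloro-3-methylphenyl group, so the evidence is indirect. The expected step is a 1.2-fold higher number from compound 3 to compound 4 (0.07 log units; within the scatter) in this assay and no change beyond the scatter is expected in either direction. Compound 4 is estimated at 40 mL/min/kg within an expected range from 20 mL/min/kg to 70 mL/min/kg on this read-out.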

Compound 4, clearance: 65 mL/min/kg
Estimate against measurement, compound 4: 1.6-fold (0.21 log units) below; the range from low to high includes it.
By their numbers in this assay, from the lowest: compounds 3, 2, 4 and 1 (each within the scatter of the next).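

In this assay, putting 4-chloro-3-methylphenyl in place of 3-chloro-4-fluorophenyl on the amide-type nitrogen gives a 1.9-fold higher number from compound 3 to compound 4 (0.28 log units; within the scatter), and the new group is equally indistinguishable from the other two, with a 1.2-fold higher number from compound 2 to compound 4 (0.08 log units; within the scatter) and a 1.0-fold lower number from compound 1 to compound 4 (0.01 log units; within the scatter). Compounds 1, 2, 3 and 4 thus carry four different aromatic groups at this position, yet every step among them stays within the scatter, so this position has not yet shown a change in clearance that can be told from the noise of the assay. No available measurement bears on what lies behind these numbers.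

As far as these compounds go, it remains open whether an amine or a carboxylic acid on the aromatic group would move the clearance beyond the scatter. The same question stands for a cyclohexyl group in place of the aromatic ring on this nitrogen.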